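Compound 3: 4-methylphenyl in place of 3,4-dichlorophenyl

The compounds below may be only part of what the source reports. "The series", "measured", "known", "first", "only" and "open" are said of these compounds alone.

Compound 1 `COc1cc(/C=C/C(=O)c2sc(Nc3ccc(Cl)c(Cl)c3)nc2C)cc(OC)c1OC` in a functional assay on BGC-823 cells (Homo sapiens) for cytotoxicity, read by MTT assay; a lower number here means a stronger inhibitor, a higher number a weaker inhibitor: > 25000 nM
Compound 2 `COc1cccc(/C=C/C(=O)c2sc(Nc3ccccc3C)nc2C)c1` in this assay: > 25000 nM

Both values are limits of the assay, not numbers. For the measured compounds named here, compound 1 stands at the limit, and so does compound 2, since the limit of > 25000 nM in this assay, at which 2 of the 2 values shown sit, describes every value so far. Going by the values given here, no step between measured compounds exists. Compound 3 `COc1cc(/C=C/C(=O)c2sc(Nc3ccc(C)cc3)nc2C)cc(OC)c1OC` differs from compound 1 by 4-methylphenyl in place of 3,4-dichlorophenyl on a nitrogen on an aromatic ring. In this assay the expected step from compound 1 to compound 3 is none beyond the scatter, most likely another limit. Compound 3 is estimated at 30000 nM, between 8000 nM and 100000 nM. The expected step is a step that the limit leaves unreadable from compound 1 to compound 3.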

Compound 3, half-maximal inhibitory concentration: > 25000 nM
Compound 3: no number, only a limit; the forecaster's own chance of this, stated with the estimate: 70%; the middle value lies beyond the limit too.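

In this assay, for the compounds shown here, compound 3 gives > 25000 nM, a limit and not a number, and compound 1 is also a limit, so no step between compound 1 and compound 3 can be read. The compounds shown leave open which change to the shared core, if any, would give a readable value.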